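The compounds below may be only part of what the source reports. "The series", "measured", "known", "first", "only" and "open" are said of these compounds alone.

Compound 1 `N#CC1=C(NCC(=O)O)N(c2ccccc2)C(=O)N2CCCCC(N3CCCC3)C12` gives 81.7% in a functional assay on the whole organism (strain albino) for inhibition, with Rattus norvegicus as the target, read by paw edema, with stated times of 1 h and 2 h, at a dose of 20 mmol/kg by the intraperitoneal route (on this read-out lower numbers stand for less inhibition and higher numbers for more inhibition at the one dose given (going by the name of the read-out)), the highest of the three numbers measured, though compound 3 `N#CC1=C(/N=C/c2ccc([N+](=O)[O-])cc2)N(c2ccccc2)C(=O)N2CCCCC(N3CCCC3)C12` with 80.9% sits within the scatter of it, as the step of a number 0.8 percentage points lower from compound 1 to compound 3 (within the scatter) shows. Compound 2 `COc1ccc(/C=N/C2=C(C#N)C3C(N4CCCC4)CCCCN3C(=O)N2c2ccccc2)cc1` gives 71.6% in this assay, and the step of a number 10.1 percentage points lower from compound 1 to compound 2 (beyond the scatter) is the only one beyond the scatter; the step of a number 9.3 percentage points higher from compound 2 to compound 3 (within the scatter) is not.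

Compound 4 `N#CC1=C(NCC(=O)N2CCCCC2)N(c2ccccc2)C(=O)N2CCCCC(N3CCCC3)C12` is the next member, differing from compound 1 by piperidin-1-yl in place of hydroxy on a carbonyl carbon. Among the compounds with values here, no measured step touches this position: the two known steps from compound 1 exchange the whole carboxymethylamino group for an imine-linked aryl group, whereas here the carboxymethylamino linkage is kept and only its carbonyl substituent changes. The measured steps therefore give no direction for this change, and the spread among compounds 1, 2 and 3 in this assay is narrow. A step of no size beyond the scatter is expected, a number 4.7 percentage points lower from compound 1 to compound 4 (within the scatter). Compound 4 is accordingly estimated at 77% in this assay, within a range of 62% to 90%.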

Compound 4, a percentage reported as inhibition, in the whole organism at one dose (the size of the read-out at that dose, not a potency): 46.1%
Beside the measured number, compound 4's estimate is 30.9 percentage points above it; the whole stated range lies above it.
By their numbers in this assay, from the lowest: compound 4; then compounds 2, 3 and 1 (each within the scatter of the next, the first and the last beyond it).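

Within the data shown here, on a carbonyl carbon, piperidin-1-yl in place of hydroxy gives a number 35.6 percentage points lower from compound 1 to compound 4 (beyond the scatter) in this assay; this is the first measured change at this position, and it is larger than any step among the earlier compounds. The same result shows that keeping the (carboxymethyl)amino linkage does not by itself hold the read-out, since compound 4 shares that linkage with compound 1, yet the imine-linked compounds lie above it, with a number 34.8 percentage points lower from compound 3 to compound 4 (beyond the scatter) and a number 25.5 percentage points lower from compound 2 to compound 4 (beyond the scatter). Nothing available bears on the reason for this fall.

The compounds shown cannot separate the departure of hydroxy from the arrival of piperidin-1-yl. A methoxy, a dimethylamino or a morpholin-4-yl group on the same carbonyl carbon would test that, and a longer chain ending in a carboxylic acid would test the carboxymethyl length.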